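The source may report more compounds than this note shows. Statements on the series, on what has been measured and on what is new or still open speak of the compounds shown alone.

Measured so far in a functional assay on KB cells (Homo sapiens) for inhibition, read by MTT assay, with a stated time of 24 h, tested at 1 ug/mL; a lower number here means less inhibition of growth, a higher number more inhibition of growth at the concentration tested:

compound 1 `O=C(CCCCC(S)CCS)Nc1ccc(Cl)cc1`: 13.4%
compound 2 `Cc1cccc(NC(=O)CCCCC(S)CCS)c1`: 3.31%

Compound 1, at 13.4%, holds the higher of the two numbers in this assay. Compound 2 reads 3.31%, and the gap between them lies beyond the scatter. Going by the values given here, both numbers sit near the bottom of the scale, so the series so far shows little inhibition of growth at the concentration tested.

Next in line is compound 3 `O=C(CCCCC(S)CCS)Nc1ccc([N+](=O)[O-])cc1`, which keeps the core of compound 1 and carries nitro in place of chloro on an aromatic carbon, para to a large group: nitro in place of chloro on an aromatic carbon.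

Among the compounds with values here, no measured pair isolates a change at this place, so the size of the step cannot be read from the data. Within the data shown here, with only two low values as a guide, compound 1 at 13.4% is the natural anchor, and no step beyond the scatter is expected, in either direction. The expected change is a number 3.4 percentage points lower from compound 1 to compound 3 (within the scatter). For compound 3 the estimated value is 10%, with an expected range from 2% to 24%.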

Compound 3, percent growth inhibition at one concentration: 0.93%
For compound 3 the middle estimate is 9.1 percentage points above the measured one; the measured number lies below the stated range.
By their numbers in this assay, from the lowest: compounds 3 and 2 (each within the scatter of the next); then compound 1.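

In this assay the aromatic carbon para to a large group now has its first measured step: nitro in place of chloro goes with a number 12.5 percentage points lower from compound 1 to compound 3 (beyond the scatter), so the reading at this place does depend on the group it carries. Compound 3 gives 0.93% and compound 1 gives 13.4%, which leaves chloro with the higher reading of this pair, although both numbers sit low on the scale and the step is modest. No measured data on either group bear on the drop, so it stands as an observation on this one pair.

An amine or a carboxylic acid at the same aromatic carbon would show whether the low reading of compound 3 extends beyond nitro, and bromo would show whether the higher reading of compound 1 extends beyond chloro. With a single pair at this place and a single tested concentration, the compounds shown give no trend across groups and no indication of how the readings would behave at other concentrations.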